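Chalcone series: halogen pattern on the aryl ring

The source may hold more compounds than are shown below. What is called first, only, known or untested is meant among the compounds shown, and "the series" means these compounds.

Two compounds carry the shared core seen in compound 1 `O=C(COc1ccc(C(=O)/C=C/c2ccccc2Br)cc1)N[C@H]1CCOC1=O` and compound 2 `O=C1OCC[C@@H]1NC(=S)SCCOc1ccc(Cl)cc1`. In a functional assay on MGC-803 cells (Homo sapiens) for antiproliferative activity, read by MTT assay, with a stated time of 72 h (on this read-out lower numbers stand for stronger inhibition and higher numbers for weaker inhibition), compound 1 gives 12200 nM, the lowest of the two numbers recorded. Compound 2 gives 51100 nM in this assay, a higher number than compound 1, and the gap between the two lies beyond the scatter of repeated measurements. Among the compounds with values here, no pair of measured compounds differs in a single place, so no measured step is available to anchor the next change.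

Compound 3 `O=C(COc1ccc(C(=O)/C=C/c2ccc(Cl)cc2Cl)cc1)N[C@H]1CCOC1=O` has not yet been measured in this assay. Relative to compound 1 it carries 2,4-dichlorophenyl in place of 2-bromophenyl on a double-bonded chain carbon bound to a double-bonded chain carbon. The two halogenated aryl groups are of similar size and neither adds a donor or acceptor, so the change is expected to move the number little in this assay: the step from compound 1 to compound 3 is estimated as a 1.4-fold lower number from compound 1 to compound 3 (0.13 log units; within the scatter), a shift that may fall within the scatter, with a slight lean toward a lower number. Compound 3 is therefore expected to give about 9000 nM in this assay, within a range of 3500 nM to 25000 nM.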

Compound 3, half-maximal inhibitory concentration: 26500 nM
Beside the measured number, compound 3's estimate is 2.9-fold (0.47 log units) below it, and the stated range ends below it.
By their numbers in this assay, from the lowest: compound 1; then compounds 3 and 2 (each within the scatter of the next).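

The aryl group on a double-bonded chain carbon bound to a double-bonded chain carbon now has its first single-place step: in this assay, 2,4-dichlorophenyl in place of 2-bromophenyl gives a 2.2-fold higher number from compound 1 to compound 3 (0.34 log units; beyond the scatter), modest but beyond the scatter. This position therefore responds to the halogen pattern, even though the groups differ little in what is counted, with 7 heavy atoms leaving, 8 entering, and 0 hydrogen-bond donors or acceptors on either side. No measurement at hand offers a reason for this shift.

From the compounds shown here alone, this single step changes both the halogen element and the substitution pattern, so it remains open whether 2-chlorophenyl at this place would read closer to compound 1 or to compound 3, a comparison that would separate the two changes. Also open, going by these compounds, is how a phenyl group carrying no halogen at all, such as 2-methoxyphenyl or 4-aminophenyl, would read here in this assay, and with it whether halogen is needed at this place.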